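Hydroxy for fluoro in a growth inhibition series

A few compounds are considered here, and "the series" means these few. Any claim that something is new, unique, unknown or untested is made for them only; others in the source may bear on it.

Of the compounds shown here, three on a shared core have numbers so far. In a functional assay on MOLT-4 cells (Homo sapiens) for inhibition (a lower number here means a stronger inhibitor of growth, a higher number a weaker inhibitor of growth), compound 1 `COc1cc(/C=C/c2ccc(S(N)(=O)=O)cc2)cc(OC)c1` stands at 18600 nM and compound 2 `NS(=O)(=O)c1ccc(/C=C/c2ccc(O)c(O)c2)cc1` at 12800 nM while compound 3 `NS(=O)(=O)c1ccc(/C=C/c2ccc(F)cc2)cc1` reads 12900 nM and so lies within the usual scatter of both. The three values therefore give no firm order among these compounds.

Compound 4 `NS(=O)(=O)c1ccc(/C=C/c2ccc(O)cc2)cc1` has not yet been measured. Its structure departs from that of compound 3 by hydroxy in place of fluoro on an aromatic carbon and the rest of the molecule stays the same. Among the measured compounds shown here, no measured pair shows this exchange on its own. Compound 2, which also carries hydroxy, stands at 12800 nM within the scatter of compound 3, so no step beyond the scatter is expected in this assay for this exchange. The estimated change a 1.1-fold lower number from compound 3 to compound 4 (0.03 log units; within the scatter) is expected to be small and has no firm direction. Compound 4 is estimated at 12000 nM with an expected range from 5000 nM to 28000 nM when it is measured.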

Compound 4, concentration for 50% growth inhibition: 22600 nM
Compound 4: middle estimate off by 1.9-fold (0.27 log units), on the low side, within the range that was stated.
By their numbers in this assay, from the lowest: compounds 2, 3, 1 and 4 (each within the scatter of the next).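

Read in this assay as a direct pair, hydroxy in place of fluoro on an aromatic carbon, para to a large group, stays within the scatter (a 1.8-fold higher number from compound 3 to compound 4 (0.24 log units; within the scatter)). Among the compounds shown here, this is the first direct reading of that exchange, and it gives no firm order between the two groups at this position. A second one-place change, hydrogen in place of hydroxy on an aromatic carbon, also stays within the scatter (a 1.8-fold higher number from compound 2 to compound 4 (0.25 log units; within the scatter)), so compound 2 and compound 4 cannot be told apart either.

On these data alone, whether an amine or a carboxylic acid at the same position would move the number beyond the scatter remains open. Nothing at hand bears on why fluoro and hydroxy read alike here.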